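The source may hold more compounds than are shown below. What is called first, only, known or untested is meant among the compounds shown, and "the series" means these compounds.

Working notes on the series. The shared core is a saturated six-membered ring with one nitrogen, carrying two phenyl groups and a methoxime; compound 1 `CO/N=C1\C[C@@H](c2ccccc2)N[C@@H](c2ccccc2)C1` is the unsubstituted parent. In a functional assay on HeLa cells (Homo sapiens) for inhibition, read by MTT assay, with a stated time of 24 h (on this read-out lower numbers stand for stronger inhibition and higher numbers for weaker inhibition), compound 1 gives 121000 nM, the highest of the three numbers recorded so far. Compound 2 `CO/N=C1\C[C@@H](c2ccc(Br)cc2)N[C@@H](c2ccc(Br)cc2)[C@@H]1C` gives 25000 nM in this assay, and compound 3 `CO/N=C1\C[C@@H](c2cccc(F)c2)N[C@@H](c2cccc(F)c2)[C@@H]1C` gives 38400 nM; both lie lower than compound 1 by more than the usual scatter, compound 3 being the nearer of the two. For the measured compounds named here, each of these differs from compound 1 in more than one place, since both carry halogen substituents on the phenyl groups and a methyl group on the core, so no single-point step has been recorded and neither of the two can be charged to one change alone.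

Compound 4 `CO/N=C1\C[C@@H](c2ccccc2)N[C@@H](c2ccccc2)[C@@H]1C(C)C` has not been measured. It differs from compound 1 as follows: isopropyl in place of hydrogen on a saturated ring carbon. Going by the values given here, no step with a single change is available to calibrate this. Given the unbranched alkyl already present in compounds 2 and 3 alongside their halogens, a modest move toward lower numbers, or none beyond the scatter, is the expectation for this assay. Compound 4 is therefore estimated at 70000 nM, within 25000 nM to 200000 nM, which would mean an expected step of a 1.7-fold lower number from compound 1 to compound 4 (0.24 log units; within the scatter).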

Compound 4, half-maximal inhibitory concentration: 49500 nM
Compound 4: middle estimate off by 1.4-fold (0.15 log units), on the high side; measured number inside the range.
By their numbers in this assay, from the lowest: compounds 2, 3 and 4 (each within the scatter of the next); then compound 1.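

For the compounds shown here, the step in this assay, a 2.4-fold lower number from compound 1 to compound 4 (0.39 log units; beyond the scatter), is the first single-change step, and it shows that this saturated ring carbon, two ring bonds from the ring nitrogen, can take an isopropyl group in place of hydrogen with a modest move toward lower numbers. Compound 4 carries no halogen on its phenyl groups, so a move beyond the scatter from the parent does not depend on halogen substituents, although the separate shares of halogen and methyl in the other two compounds remain unresolved. No measurement bears on why the isopropyl group has this effect, so the step stands as an observation without an explanation.

The compounds shown leave open how the number responds to other groups on this same carbon, such as an ethyl group, a longer chain like n-butyl, a hydroxyl group, an amine or a carboxylic acid. They also leave open whether an isopropyl group here would give a further shift when combined with bromine or fluorine on the phenyl groups.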